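A Benzylamino Analogue and Its Expected Cytotoxicity

This account rests on a few compounds, and the source may have more. Where it says the series, first, only, none or still open, it means among the compounds named here.

Compound 2 `CCN(CC)c1cc2[nH]c(C3CCCCC3)nc2cc1NC(=O)c1ccc(OC(F)(F)F)cc1` and compound 1 `CN(C)c1cc2[nH]c(C3CCCCC3)nc2cc1NC(=O)c1ccc(Br)cc1` share one core. In an ADME assay on Vero cells (Chlorocebus sabaeus) for cytotoxicity, read by resazurin assay, with a stated time of 3 days (a lower number here means a stronger inhibitor, a higher number a weaker inhibitor), compound 2 reaches only a limit, > 100 ug/mL. Compound 1 likewise gives only a limit in this assay, > 100 ug/mL. Compound 2 therefore stands at the limit of > 100 ug/mL in this assay, at which 2 of the 2 values shown sit. Compound 3 `CCN(CC)c1cc2[nH]c(C3CCCCC3)nc2cc1NC(=O)NCc1ccccc1` differs from compound 2 in one place: benzylamino in place of 4-(trifluoromethoxy)phenyl on a carbonyl carbon. Among the compounds with values here, no step between measured compounds is known here, so the estimated step that the limit leaves unreadable from compound 2 to compound 3 is none beyond the scatter, expected because compound 2 sits at the limit of > 100 ug/mL in this assay, at which 2 of the 2 values shown sit. Compound 3 is expected to give about 120 ug/mL, within 60 ug/mL to 250 ug/mL.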

Compound 3, half-maximal inhibitory concentration: > 100 ug/mL
Compound 3 ended at the assay's limit; the forecaster's own chance of this, stated with the estimate: 75%; the middle value does not contradict the limit.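

Within the data shown here, compound 2 and compound 3 both end at a limit in this assay, so no step between them can be read: the limit of > 100 ug/mL in this assay, at which 3 of the 3 values shown sit.

The compounds shown leave open whether benzylamino in place of 4-(trifluoromethoxy)phenyl changes cytotoxicity at all.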